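The source may hold more compounds than are shown below. What is called first, only, known or untested is meant among the compounds shown, and "the series" means these compounds.

Measured so far in an ADME assay on microsomes from liver (Canis lupus familiaris) for metabolic stability, read by LC-MS, using NADPH, with a stated time of 30 min, tested at 1 uM; on this read-out higher numbers stand for a more stable compound and lower numbers for a less stable compound:
- compound 1 `C=CC(=O)Nc1cc(Nc2ncc(I)c(Nc3ccccc3S(=O)(=O)N(C)C)n2)c(OC)cc1N(C)CCN(C)C` gives 35%
- compound 2 `C=CC(=O)Nc1cc(Nc2ncc(Cl)c(Nc3ccccc3S(=O)(=O)C(C)C)n2)c(OC)cc1N(C)CCN(C)C` gives 17%

Compound 2 holds the lower of the two numbers, and compound 1 lies higher by more than the usual scatter. Compound 3 `C=CC(=O)Nc1cc(Nc2ncc(Cl)c(Nc3ccccc3S(=O)(=O)N(C)C)n2)c(OC)cc1N(C)CCN(C)C` has dimethylamino in place of isopropyl on a sulfonyl sulfur of compound 2 (dimethylamino in place of isopropyl on a sulfonyl sulfur). Among the compounds with values here, no measured pair isolates this change. The expectation rests on compound 1 (35%), which also carries dimethylamino on a sulfonyl sulfur but differs from compound 3 elsewhere. An upward move beyond the scatter is expected, estimated as (a number 13 percentage points higher from compound 2 to compound 3 (beyond the scatter)). For compound 3 the estimated value is 30% (range 16% to 46%).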

Compound 3, percent of the compound remaining: 31%
Estimate against measurement, compound 3: 1 percentage points below; the range from low to high includes it.
By their numbers in this assay, from the lowest: compound 2; then compounds 3 and 1 (each within the scatter of the next).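

In this assay, dimethylamino in place of isopropyl on a sulfonyl sulfur now has a direct comparison, giving a number 14 percentage points higher from compound 2 to compound 3 (beyond the scatter) with chloro held constant. Chloro in place of iodo on an aromatic carbon gives a number 4 percentage points lower from compound 1 to compound 3 (within the scatter) with dimethylsulfamoyl held constant, so only the sulfonyl change lies beyond the scatter in this pair of steps. No supporting measurement accounts for either step.

Each change rests on one pair. Going by these compounds, whether these steps carry over to bromo on the aromatic carbon, or to methyl or morpholine on the sulfonyl sulfur, remains open.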